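Chain methylation steps in a sulfonamide series

The source may report more compounds than this note shows. Statements on the series, on what has been measured and on what is new or still open speak of the compounds shown alone.

Three compounds of this series are measured in a physicochemical assay for lipophilicity; a lower number here means a more polar compound, a higher number a more lipophilic compound. Compound 1 `CN(CCCn1cc[n+](C)c1/C=N/O)S(=O)(=O)C(F)(F)F` gives -1.37 in this assay. Compound 2 `CCN(CCCn1cc[n+](C)c1/C=N/O)S(=O)(=O)C(F)(F)F` gives -1.02. The change between these two is methyl in place of hydrogen on a saturated chain carbon bound to a sulfonamide nitrogen, and it moves this assay by a number 0.35 log units higher from compound 1 to compound 2 (beyond the scatter). Compound 3 `CC(Cn1cc[n+](C)c1/C=N/O)NS(=O)(=O)C(F)(F)F` gives -0.82; its number lies closest to that of compound 2, within the scatter, and furthest from that of compound 1, beyond the scatter. The difference between the core of compound 3 and the core of compound 1 is not broken down here.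

Compound 4 `CCC(Cn1cc[n+](C)c1/C=N/O)NS(=O)(=O)C(F)(F)F` is not yet measured. It differs from compound 3 by methyl in place of hydrogen on a saturated chain carbon, two bonds along the chain from a sulfonamide nitrogen. Going by the values given here, this is the same kind of change as the one from compound 1 to compound 2, but not the same change: there the methyl enters on a saturated chain carbon bound to a sulfonamide nitrogen, here on a saturated chain carbon two bonds along the chain from a sulfonamide nitrogen. A step of similar size is expected, a number 0.35 log units higher from compound 3 to compound 4 (beyond the scatter), because the same kind of change gave a number 0.35 log units higher from compound 1 to compound 2 (beyond the scatter). Compound 4 is therefore expected to give about -0.47, estimated to fall between -0.75 and -0.2.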

Compound 4, distribution coefficient: -0.42
For compound 4 the middle estimate is 0.05 log units below the measured one, and the stated range covers the measured number.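

In this assay methyl in place of hydrogen gives a number 0.40 log units higher from compound 3 to compound 4 (beyond the scatter) on the core of compound 3 and gives a number 0.35 log units higher from compound 1 to compound 2 (beyond the scatter) on the core of compound 1, so across these two pairs the change carries over in the same direction. This rests on two pairs only and does not establish a rule for other cores: the methyl enters at different places, on a saturated chain carbon bound to a sulfonamide nitrogen in compound 2 and on a saturated chain carbon two bonds along the chain from a sulfonamide nitrogen in compound 4. Nothing available explains the origin of either step.

The compounds shown leave open how a longer chain such as propyl, an amine or a carboxylic acid would read in this assay at the place of this methyl. They also leave open whether the methyl step would carry over to a third core.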